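The source may report more compounds than this note shows. Statements on the series, on what has been measured and on what is new or still open speak of the compounds shown alone.

Compound 3 (`Cc1nc(C#Cc2ccc(OS(C)(=O)=O)nc2)cs1`) gives 2340 nM in a functional assay on CHO cells for agonist activity at metabotropic glutamate receptor 5 (Homo sapiens), read by inositol phosphate accumulation (on this read-out lower numbers stand for stronger inhibition and higher numbers for weaker inhibition), the highest number among the three compounds measured. Compound 1 (`CCc1sc(C)nc1C#Cc1cccnc1`) gives 1240 nM in this assay, a value within the usual scatter of that of compound 3, while compound 2 (`C#Cc1cncc(C#Cc2csc(C)n2)c1`) gives 19.2 nM, a far lower number that lies well beyond the scatter. Compound 4 (`C=Cc1ccc(C#Cc2csc(C)n2)cn1`) differs from compound 3 in one place: vinyl in place of (methylsulfonyl)oxy on an aromatic carbon. Going by the values given here, no measured pair shows this change directly, so the size of the step is open. Because compound 2, carrying a small unsaturated group on its pyridine, gives 19.2 nM, compound 4 is expected to show a lower number than compound 3, by a step of a 7.8-fold lower number from compound 3 to compound 4 (0.89 log units; beyond the scatter). For compound 4 the estimate is 300 nM, with a range from 60 nM to 1500 nM.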

Compound 4, half-maximal inhibitory concentration: > 10000 nM
Compound 4: a limit, no number; the forecaster's own chance of this, stated with the estimate: 5%; middle value at least 33-fold (1.52 log units) away from the limit.
By their numbers in this assay, from the lowest: compound 2; then compounds 1 and 3 (each within the scatter of the next). At a limit, above all of these: compound 4.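

Compound 4 stands at a limit and not at a number: the limit of > 10000 nM in this assay, at which 1 of the 4 values shown sits.

Going by these compounds alone, this is the first direct reading at this position, on an aromatic carbon next to the ring nitrogen. Vinyl in place of (methylsulfonyl)oxy gives an at least 4.2-fold higher number from compound 3 to compound 4 (0.63 log units; beyond the scatter) in this assay, so this change moves the number up, not down, and the full size of the step stays hidden behind the limit.

As far as these compounds go, whether an amine, a methoxy group or a longer chain on this carbon would give a lower number than compound 3 stays open.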